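The source may report more compounds than this note shows. Statements on the series, on what has been measured and on what is new or still open speak of the compounds shown alone.

Values in an assay on isolated protein for inhibition of aldehyde dehydrogenase 1A1 (Homo sapiens), read by spectrophotometry, tested at 10 uM; on this read-out higher numbers stand for more inhibition at the one concentration tested (going by the name of the read-out) and lower numbers for less inhibition:
compound 1 `CCC(=O)N1CCN(Cc2nc3ccccc3n2Cc2cccc(C)c2)CC1`: 85.1%
compound 2 `O=C(C1CC1)N1CCN(Cc2nc3ccccc3n2Cc2ccccc2)CC1`: 23.9%
compound 3 `O=C(C1CC1)N1CCN(Cc2nc3ccccc3n2Cc2ccc(Cl)cc2)CC1`: 56.6%

Compound 1 stands highest of the three numbers in this assay; compound 3 comes nearest and lies lower, compound 2 lies lowest, both gaps beyond the scatter. Among the compounds with values here, the one step measured, a number 32.7 percentage points higher from compound 2 to compound 3 (beyond the scatter), concerns an aromatic carbon and leaves the carbonyl substituent untouched.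

Compound 4 `Cc1cccc(Cn2c(CN3CCN(C(=O)c4ccncc4)CC3)nc3ccccc32)c1` is compound 1 with a single change on the carbonyl carbon: pyridin-4-yl in place of ethyl on a carbonyl carbon. Within the data shown here, no measured pair alters the group on the carbonyl carbon, so the step from compound 2 to compound 3 does not bear on this change, and compounds 2 and 3 differ from compound 1 in more than one place, so their values alone say nothing about the acyl group. The starting number of compound 1, 85.1%, leaves little room upward, and the change is large in count of atoms and brings a ring and an acceptor where a short chain stood, so a step of a number 17.1 percentage points lower from compound 1 to compound 4 (beyond the scatter) is expected, downward, with wide uncertainty. Compound 4 is therefore expected to give about 68% in this assay, within 35% to 95%.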

Compound 4, a percentage reported as inhibition, at one concentration (the size of the read-out at that concentration, not a potency): 20.6%
Beside the measured number, compound 4's estimate is 47.4 percentage points above it, and the stated range ends above it.
By their numbers in this assay, from the lowest: compounds 4 and 2 (each within the scatter of the next); then compound 3; then compound 1.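

In this assay, within the data shown here, the group on the carbonyl carbon proves to be a sensitive place, which the earlier compounds could not show, as their only single-place step concerned an aromatic carbon. Pyridin-4-yl in place of ethyl gives a number 64.5 percentage points lower from compound 1 to compound 4 (beyond the scatter) and so removes most of the inhibition seen at the one concentration tested, a large step from a single change with the rest of the structure held fixed. The high reading therefore belongs to the shared core together with the small acyl group propanoyl and does not carry over to (pyridin-4-yl)carbonyl, though nothing at hand links the loss to any particular feature of the entering group.

Still open, from the compounds shown here alone, is whether the loss follows the size of the entering group, its aromatic ring or its ring nitrogen, and a plain phenyl group or a longer chain such as butanoyl on the same carbonyl carbon would begin to separate these. Also open, going by these compounds, is how the cyclopropyl group of compound 2 and compound 3 would read on the core of compound 1.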